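Shortening the alkyl chain of trifluoromethyl ketone inhibitors

This account rests on a few compounds, and the source may have more. Where it says the series, first, only, none or still open, it means among the compounds named here.

Compound 3 `CCCCCCCCCC(=O)C(F)(F)F` stands lowest of the three numbers in an assay for inhibition of Fatty-acid amide hydrolase 1 (Rattus norvegicus); on this read-out higher numbers stand for weaker inhibition and lower numbers for stronger inhibition; compound 1 `CCCCCCCCCCCCCCCCCC(=O)C(F)(F)F` gives 1200 nM, and compound 2 `CCCCCCCCCCCCCC(=O)C(F)(F)F` gives 2300 nM, against 600 nM for compound 3. The step of a 1.9-fold higher number from compound 1 to compound 2 (0.28 log units; within the scatter) lies within the scatter, whereas a 3.8-fold lower number from compound 2 to compound 3 (0.58 log units; beyond the scatter) is a modest gain. Compound 4 `CCCCCCC(=O)C(F)(F)F` differs from compound 3 by hydrogen in place of propyl on a saturated chain carbon, six bonds along the chain from a carbonyl carbon. Both measured steps are chain shortenings, so both bear on this one, but they disagree in size and direction, and neither touches the chain this close to the carbonyl. No basis exists for a confident direction; a step within the scatter to a modest one is expected in this assay, with a loss held somewhat more likely given that the smallest member so far is the strongest only by the step from compound 2. Compound 4 is therefore expected to give 1500 nM, between 400 nM and 6000 nM, which means an expected step of a 2.5-fold higher number from compound 3 to compound 4 (0.40 log units; beyond the scatter).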

Compound 4, half-maximal inhibitory concentration: 52800 nM
For compound 4 the middle estimate is 35-fold (1.55 log units) below the measured one; the measured number lies above the stated range.
By their numbers in this assay, from the lowest: compounds 3, 1 and 2 (each within the scatter of the next, the first and the last beyond it); then compound 4.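

Shortening the chain here, with hydrogen in place of propyl six bonds along the chain from a carbonyl carbon, gives a large loss in this assay and shows an 88-fold higher number from compound 3 to compound 4 (1.94 log units; beyond the scatter). The earlier steps shown here gave no sign of this, since a 1.9-fold higher number from compound 1 to compound 2 (0.28 log units; within the scatter) stays within the scatter and a 3.8-fold lower number from compound 2 to compound 3 (0.58 log units; beyond the scatter) is a modest gain, so chain shortening does not act in one direction across this series. Nothing available explains the size or the reversal of this step.

Open, from the compounds shown here alone, is how the number changes for chain lengths falling between those of compound 3 and compound 4, and so whether the loss comes gradually or abruptly. Also open, going by these compounds, is whether a carboxylic acid or an amine carried on the short chain of compound 4 would recover any of the loss.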